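The source may hold more compounds than are shown below. What is called first, only, known or untested is meant among the compounds shown, and "the series" means these compounds.

In a functional assay on HeLa cells (Homo sapiens) for antiproliferative activity, read by MTT assay, with a stated time of 72 h (a lower number here means a stronger inhibitor, a higher number a weaker inhibitor), compound 1 `CCCCCn1ccnc1-c1cc(OC)c(OC)c(OC)c1` reaches only a limit, > 100000 nM. Within the data shown here, compound 2 `COc1cc(-c2nccn2-c2ccc(F)cc2)cc(OC)c1OC` gives 17500 nM, the only true number so far. Compound 3 `COc1ccc(-n2ccnc2-c2cc(OC)c(OC)c(OC)c2)cc1` differs from it at one place: methoxy in place of fluoro on an aromatic carbon, methoxy in place of fluoro, para to a large group. Among the measured compounds shown here, the single measured step, an at least 5.7-fold lower number from compound 1 to compound 2 (0.75 log units; beyond the scatter), replaces pentyl with 4-fluorophenyl on an aromatic nitrogen and rests on the limit (the limit of > 100000 nM in this assay, at which 1 of the 2 values shown sits). For the measured compounds named here, it shows that this substituent can move the number, but no measured step covers the new change. A modest move toward a lower number is expected, estimated as a 3.5-fold lower number from compound 2 to compound 3 (0.54 log units; beyond the scatter). The estimate for compound 3 is 5000 nM, with an expected range of 400 nM to 40000 nM.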

Compound 3, half-maximal inhibitory concentration: 1200 nM
Estimate against measurement, compound 3: 4.2-fold (0.62 log units) above, within the range that was stated.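

In this assay, the aromatic carbon para to a large group proves sensitive to a single swap: methoxy in place of fluoro gives a 15-fold lower number from compound 2 to compound 3 (1.16 log units; beyond the scatter). So the substituent on this aryl group moves the number, not only the aryl group's presence on the aromatic nitrogen. The change from pentyl to 4-methoxyphenyl gives an at least 83-fold lower number from compound 1 to compound 3 (1.92 log units; beyond the scatter), but compound 1 gives only a limit, so this step is a bound: the limit of > 100000 nM in this assay, at which 1 of the 3 values shown sits.

Open, from the compounds shown here alone, is how an ethoxy group, a hydroxyl or an amine at this carbon would compare with methoxy. Also open, going by these compounds, is whether the same swap would move the number at another carbon of this ring.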